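The source may report more compounds than this note shows. Statements on the series, on what has been measured and on what is new or still open speak of the compounds shown alone.

Compound 2 `O=C(Nc1cccc(F)c1)c1cccc(/C=C2\CC(=O)N(c3ccccc3)C2=O)c1` stands only at a limit in an ADME assay on SW480 cells (Homo sapiens) for cytotoxicity, read by MTT assay, with a stated time of 72 h; on this read-out higher numbers stand for weaker inhibition and lower numbers for stronger inhibition: in this assay compound 2 gives > 100000 nM, which is the edge of what the assay can report rather than a number (the limit of > 100000 nM in this assay, at which 1 of the 2 values shown sits). Compound 1 `CCCCCN1C(=O)C/C(=C\c2cccc(C(=O)Nc3cccc(CC)c3)c2)C1=O`, which already carries a pentyl on the amide-type nitrogen in the ring but a different amide partner, gives 83300 nM in this assay, a weak effect that does lie inside the measurable range. Compound 3 `CCCCCN1C(=O)C/C(=C\c2cccc(C(=O)Nc3cccc(F)c3)c2)C1=O` has not yet been measured. It differs from compound 2 in one place: pentyl in place of phenyl on an amide-type nitrogen in a ring, so it carries the same pentyl as compound 1 while keeping the amide partner of compound 2. Among the measured compounds shown here, no measured pair shows this exchange on its own, and the step can only be judged from where compound 1 stands. Compound 3 is expected to stay weak, and the step of an at least 1.1-fold lower number from compound 2 to compound 3 (0.04 log units; that floor lies within the scatter) is expected to be none beyond the scatter, with a real chance that the assay again reports only a limit. Compound 3 is estimated at 90000 nM, in a range from 40000 nM to 200000 nM.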

Compound 3, half-maximal inhibitory concentration: > 100000 nM
Compound 3 was reported as a limit; the forecaster's own chance of this, stated with the estimate: 45%; middle value at least 1.1-fold (0.04 log units) away from the limit.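

In this assay compound 3 gives > 100000 nM, which is a limit of the assay and not a number, so with the fluoro amide partner, pentyl in place of phenyl on the amide-type nitrogen in the ring gives no value inside the measurable range. Among the compounds shown here, the size of that exchange cannot be read, as the values on both sides of it are limits, and such limits now make up most of this small set: the limit of > 100000 nM in this assay, at which 2 of the 3 values shown sit. The one readable comparison is fluoro in place of ethyl on an aromatic carbon, with the pentyl kept, which gives an at least 1.2-fold higher number from compound 1 to compound 3 (0.07 log units; that floor lies within the scatter); this floor alone does not establish a change beyond the scatter.

On these data alone, it remains open whether phenyl and pentyl differ at all at this nitrogen, since any real difference could lie beyond what the assay can report. As far as these compounds go, it is also open whether a longer chain such as decyl, or a chain ending in an amine, on that nitrogen would bring the fluoro compound into the measurable range.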